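Ethylsulfonyl for cyclopropylcarbonyl on the shared spiro core

This account rests on a few compounds, and the source may have more. Where it says the series, first, only, none or still open, it means among the compounds named here.

Compound 1 `CCCN1C(N)=NC(N)=NC12CCN(C(=O)C1CC1)CC2` gives > 100000 nM in an ADME assay on MDCK cells (Canis lupus familiaris) for cytotoxicity, read by microscopy, with a stated time of 6 days (on this read-out lower numbers stand for higher toxicity in this test and higher numbers for lower toxicity in this test), a limit of the assay.
Compound 2 `COCCN1C(N)=NC(N)=NC12CCN(C(=O)C1CC1)CC2` gives > 100000 nM in this assay, again a limit.
Compound 3 `COCCN1C(N)=NC(N)=NC12CCN(C(=O)Nc1ccc(OC)cc1)CC2` gives > 100000 nM, also a limit.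

Compound 2 thus stands at the assay limit, as do the other two values shown (the limit of > 100000 nM in this assay, at which 3 of the 3 values shown sit). The step to compound 4 `CCS(=O)(=O)N1CCC2(CC1)N=C(N)N=C(N)N2CCOC` is ethylsulfonyl in place of cyclopropylcarbonyl on an amine nitrogen in a ring. The measured steps a step that the two limits leave unreadable from compound 1 to compound 2 and a step that the two limits leave unreadable from compound 2 to compound 3 bear on it only loosely, and neither has a readable size, so no change beyond the scatter is expected. Compound 4 is estimated at 100000 nM, between 50000 nM and 200000 nM, most likely reported as a limit. The expected step is a number no higher from compound 2 to compound 4 (the limit leaves the size open).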

Compound 4, minimum cytotoxic concentration: > 100000 nM
Compound 4 gave a limit, no number (the forecaster's own chance of this, stated with the estimate: 85%); the middle value sits exactly at the limit.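

Compound 2 and compound 4 both give only a limit in this assay, so no step between them can be read: the limit of > 100000 nM in this assay, at which 4 of the 4 values shown sit.

The compounds shown leave open at what concentration any of them would become cytotoxic, and whether ethylsulfonyl and cyclopropylcarbonyl differ at all.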